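Fluorine Placement in a Urea Series Tested on Rice

The compounds below may be only part of what the source reports. "The series", "measured", "known", "first", "only" and "open" are said of these compounds alone.

Compound 1 `C[C@H](NC(=O)Nc1ccccc1F)c1ccccc1`: 65%
Compound 2 `C[C@@H](NC(=O)Nc1ccc(F)cc1)c1ccccc1`: 92%
Compound 3 `C[C@H](NC(=O)Nc1ccc(F)cc1F)c1ccccc1`: 99%

All three compounds were tested in an ADME assay on the whole organism with Oryza sativa as the target, tested at 10 uM; a lower number here means a stronger effect, a higher number a weaker effect of the compound at the concentration tested. Compound 1 gives 65%, and compound 3 gives 99%. The two differ by fluoro in place of hydrogen on an aromatic carbon, and this change made a step of a number 34 percentage points higher from compound 1 to compound 3 (beyond the scatter), so adding the second fluorine in that position clearly weakened the effect. Compound 2 has the same atoms as compound 1, joined differently; the difference between these two cores is not broken down here. In this assay compound 2 gives 92%, which sits in the same range as compound 3 and well apart from compound 1.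

Compound 4 `C[C@@H](NC(=O)Nc1ccc(F)c(F)c1)c1ccccc1` has not yet been measured. It differs from compound 2 by fluoro in place of hydrogen on an aromatic carbon. This is the same kind of change as from compound 1 to compound 3, but not the same: there the entering fluoro sits meta to a fluoro group and para to a large group, here it sits ortho to a fluoro group and meta to a large group. The earlier step was large, but compound 2 already gives a number close to the top of the scale, which leaves little room for a rise of that size. The step from compound 2 to compound 4 is therefore expected to be about a number 4 percentage points higher from compound 2 to compound 4 (within the scatter). For compound 4 the estimated number is 96%, expected to fall between 85% and 100%.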

Compound 4, a percentage reported as activity, at one concentration (the size of the read-out at that concentration, not a potency): 96%
Compound 4: middle estimate and measured number agree at the digits printed; measured number inside the range.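

In this assay the added fluoro gives a number 4 percentage points higher from compound 2 to compound 4 (within the scatter), so on this core the change cannot be told apart from no change at all. Set side by side, the two steps show that the same swap of hydrogen for fluoro did not keep its size when moved from one core to the other: the same change on two cores in this assay, a number 34 percentage points higher (beyond the scatter) from compound 1 to compound 3 and a number 4 percentage points higher (within the scatter) from compound 2 to compound 4, 30 percentage points apart, beyond the scatter of two such steps. This does not show why the two steps differ, and two cases give no rule for a further core, since the entering fluoro also stands in a different place relative to the other groups in each case and compound 2 already gives a number close to the top of the scale.

The compounds shown carry only fluoro groups on the ring attached to the urea, so it remains open how a chloro group, a methoxy group or an amine on that ring would read in this assay. From the compounds shown here alone, it also remains open whether a longer chain in place of the methyl group on the carbon joined to the urea nitrogen would change the read-out.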